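This account rests on a few compounds, and the source may have more. Where it says the series, first, only, none or still open, it means among the compounds named here.

Working notes on the series.

Three compounds share one core, each carrying a trifluoromethyl-bearing phenyl and two hydroxyphenyl groups, differing only in where the hydroxyl sits on one of them: compound 1 `Oc1ccccc1-c1cc(-c2ccc(C(F)(F)F)cc2)cc(-c2ccccc2O)n1`, compound 2 `Oc1cccc(-c2cc(-c3ccc(C(F)(F)F)cc3)cc(-c3ccccc3O)n2)c1` and compound 3 `Oc1ccc(-c2cc(-c3ccc(C(F)(F)F)cc3)cc(-c3ccccc3O)n2)cc1`. In a functional assay on T47D cells (Homo sapiens) for inhibition (a lower number here means a stronger inhibitor, a higher number a weaker inhibitor), compound 1 gives > 50000 nM, which is a limit of the assay and not a number. In this assay compound 2 gives > 50000 nM, also a limit. In this assay compound 3 gives > 50000 nM, again a limit. Accordingly the steps a step that the two limits leave unreadable from compound 1 to compound 2, a step that the two limits leave unreadable from compound 1 to compound 3 and a step that the two limits leave unreadable from compound 2 to compound 3 cannot be sized; all that is known is the limit of > 50000 nM in this assay, at which 3 of the 3 values shown sit.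

Compound 4 `Oc1cccc(-c2cc(-c3ccc(OC(F)(F)F)cc3)cc(-c3ccccc3O)n2)c1` departs from compound 2 by trifluoromethoxy in place of trifluoromethyl on an aromatic carbon. For the measured compounds named here, no measured step touches this part of the molecule, so the hydroxyphenyl steps give no guide beyond showing that nothing has yet left the limit. The step of a number no higher from compound 2 to compound 4 (the limit leaves the size open) is therefore an estimate with no measured anchor. Compound 4 is expected to give 50000 nM in this assay, within 15000 nM to 150000 nM, most likely again reported only as a limit.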

Compound 4, half-maximal inhibitory concentration: 7710 nM
For compound 4 the middle estimate is 6.5-fold (0.81 log units) above the measured one, outside the stated range (below it).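

In this assay the replacement of trifluoromethyl by trifluoromethoxy, para to a large group, brings an at least 6.4-fold lower number from compound 2 to compound 4 (0.81 log units; beyond the scatter), so this position can move the series off its limit where the earlier hydroxyl shifts showed no readable change. Compound 2 gives > 50000 nM, which is a limit of the assay and not a number. For the compounds shown here, the steps among compound 1, compound 2 and compound 3 cannot be read, which leaves this as the only step with a readable size: the limit of > 50000 nM in this assay, at which 3 of the 4 values shown sit.

Going by these compounds, it remains open whether the same replacement would also bring compound 1 or compound 3 off the limit, or whether its effect depends on the hydroxyl placement in compound 2. On these data alone, it is equally open how methoxy, chlorine or a longer ether chain at this position would compare with trifluoromethoxy.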